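The source may hold more compounds than are shown below. What is called first, only, known or untested is meant among the compounds shown, and "the series" means these compounds.

Measured so far in a physicochemical assay for solubility, measured as kinetic solubility, at pH 2; a higher number here means a more soluble compound, a lower number a less soluble compound:
- compound 1, `Cc1nc(-c2cccc(CNc3ccc4[nH]nc(C(=O)O)c4c3)c2O)sc1C`: 20000 nM
- compound 2, `CN(C)c1noc(-c2cccc(CN(C)c3ccc4[nH]nc(C(=O)O)c4c3)c2O)n1`: 16000 nM
- compound 3, `CN(C)c1noc(-c2cccc(CNc3ccc4[nH]nc(C(=O)O)c4c3)c2Cl)n1`: 7000 nM

Compound 1 stands highest of the three numbers. Compound 2 sits within the scatter of compound 1, so the two cannot be ordered. For the measured compounds named here, compound 3 sits beyond the scatter below compound 1 and is the only compound here that clearly separates from it. Going by the values given here, no two measured compounds differ in one place only, so no single-point step is available to lean on.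

Compound 4, `CC(C)c1coc(-c2cccc(CNc3ccc4[nH]nc(C(=O)O)c4c3)c2O)n1`, is the next compound to go into this assay. It differs from compound 1 by 4-isopropyl-1,3-oxazol-2-yl in place of 4,5-dimethyl-1,3-thiazol-2-yl on an aromatic carbon. The hydroxy group and the rest of the shared core are unchanged. Since compound 1 and compound 2 carry different five-membered rings at this position and still sit within the scatter of each other, the step from compound 1 to compound 4 is expected to stay small, a 1.3-fold lower number from compound 1 to compound 4 (0.12 log units; within the scatter), and not beyond the scatter in either direction. Compound 4 is therefore estimated at 15000 nM, with a range from 6000 nM to 35000 nM.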

Compound 4, solubility: 4000 nM
Compound 4: the middle estimate sits 3.8-fold (0.57 log units) above what was measured; the measured number lies below the stated range.
By their numbers in this assay, from the lowest: compounds 4 and 3 (each within the scatter of the next); then compounds 2 and 1 (each within the scatter of the next).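

In this assay, the aromatic carbon ortho to a hydroxy group does not tolerate every five-membered ring alike: 4-isopropyl-1,3-oxazol-2-yl in place of 4,5-dimethyl-1,3-thiazol-2-yl gives a 5.0-fold lower number from compound 1 to compound 4 (0.70 log units; beyond the scatter). For the compounds shown here, this is the first step that changes one place only, and it shows that two rings matching in their counts of hydrogen-bond donors and acceptors can still separate clearly at this position. Nothing measured here accounts for the step.

The change swaps the ring and its alkyl groups together, so the compounds shown leave open which of the two carries the step. Also open, going by these compounds, is where a 4,5-dimethyl-1,3-oxazol-2-yl group, or a ring bearing an amine, would fall on the same core with the hydroxy group kept.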